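A few compounds are considered here, and "the series" means these few. Any claim that something is new, unique, unknown or untested is made for them only; others in the source may bear on it.

Working notes on the series.

Among the compounds with values here, compound 1 `FC(F)(F)c1cnc(N2CCC(NC(=S)Nc3cccnc3)CC2)c(Cl)c1` stands lowest of the two numbers measured so far: in an assay on membranes from brain for binding affinity to Lysophosphatidylserine lipase ABHD12 (Mus musculus), read by fluorescence, with a stated time of 20 min (on this read-out higher numbers stand for weaker inhibition and lower numbers for stronger inhibition), compound 1 gives 1100 nM. Within the data shown here, its nearest neighbour is compound 2 `Cc1cnc(N2CCC(NC(=S)Nc3cccnc3)CC2)c(Cl)c1`, which in this assay gives 3100 nM; the only measured step, methyl in place of trifluoromethyl on an aromatic carbon, moves the number a 2.8-fold higher number from compound 1 to compound 2 (0.45 log units; beyond the scatter), a modest shift but beyond the scatter.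

Compound 3 `FC(F)(F)c1ccc(N2CCC(NC(=S)Nc3cccnc3)CC2)nc1` is not yet measured. The change from compound 1 is hydrogen in place of chloro on an aromatic carbon, the chloro sitting ortho to a large group, two atoms from the ring nitrogen and meta to the trifluoromethyl group on the six-membered aromatic ring with one nitrogen. Among the measured compounds shown here, no measured step touches this position; the step from compound 1 to compound 2 concerns a different substituent on the same ring and only shows that a single change on that ring can move the number modestly. The expected step is therefore small, and its direction is uncertain; a somewhat higher number is the working guess, with the estimated step of a 1.8-fold higher number from compound 1 to compound 3 (0.26 log units; within the scatter). For compound 3 in this assay the estimate is 2000 nM, within a range of 600 nM to 6500 nM.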

Compound 3, half-maximal inhibitory concentration: 1900 nM
The estimate for compound 3 lay 1.1-fold (0.02 log units) above the measured number; the measured number falls inside the stated range.
By their numbers in this assay, from the lowest: compounds 1, 3 and 2 (each within the scatter of the next, the first and the last beyond it).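

In this assay, the replacement of chloro by hydrogen on the aromatic carbon ortho to a large group, two atoms from the ring nitrogen and meta to the trifluoromethyl group, gives a 1.7-fold higher number from compound 1 to compound 3 (0.24 log units; within the scatter), so the chloro is not required for a number of this order. On the same ring, the replacement of trifluoromethyl by methyl gives a 2.8-fold higher number from compound 1 to compound 2 (0.45 log units; beyond the scatter), which lies beyond the scatter, while the step at the chloro position does not; the two positions therefore read differently on the compounds shown, though each rests on a single step from compound 1. No measurement at hand bears on the reason for this result.

Open, as far as these compounds go, is how this position responds to groups other than chloro and hydrogen, such as a methoxy group, a nitrile or an amine, which could separate from compound 1 by more than the scatter. Also open, from the compounds shown here alone, is whether hydrogen in place of chloro would give a similar step on the core of compound 2, which carries methyl instead of trifluoromethyl.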